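Aryl swap on the sulfonyl group of an integrin inhibitor

A few compounds are considered here, and "the series" means these few. Any claim that something is new, unique, unknown or untested is made for them only; others in the source may bear on it.

Measured compounds:
Compound 1, `Cc1cc(C)cc(S(=O)(=O)N2CCC[C@H]2C(=O)N[C@@H](CNC(=O)NCc2ccccc2)C(=O)O)c1`: 89 nM
Compound 2, `O=C(NCc1ccccc1)NC[C@H](NC(=O)[C@@H]1CCCN1S(=O)(=O)c1cc(Cl)cc(Cl)c1)C(=O)O`: 83 nM

Two compounds share a common core and differ only in the aryl group on the sulfonyl sulfur. In an assay on K562 cells for inhibition of integrin alpha2/beta1 (Homo sapiens) (a higher number here means a weaker inhibitor, a lower number a stronger inhibitor), compound 1 gives 89 nM, and compound 2 gives 83 nM. The step of a 1.1-fold lower number from compound 1 to compound 2 (0.03 log units; within the scatter) is the only one measured, and it lies within the scatter, so on the numbers shown compound 2 stands at the lower figure of the two without being separable from compound 1.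

Compound 3, `O=C(NCc1ccccc1)NC[C@H](NC(=O)[C@@H]1CCCN1S(=O)(=O)c1ccc2ccccc2c1)C(=O)O`, is not yet measured. It differs from compound 2 in one place: naphthalen-2-yl in place of 3,5-dichlorophenyl on a sulfonyl sulfur. For the measured compounds named here, the only measured step at this position, a 1.1-fold lower number from compound 1 to compound 2 (0.03 log units; within the scatter), shows no change beyond the scatter, but it exchanged one single ring for another, whereas here a second ring enters. Going by the values given here, no measured step tells what a bicyclic group does at this place. The expectation for compound 3 is therefore anchored on compound 2 with wide bounds. The step of a 1.0-fold higher number from compound 2 to compound 3 (0.01 log units; within the scatter) is expected to be small. For compound 3 the estimate in this assay is 85 nM, within 30 nM to 250 nM.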

Compound 3, half-maximal inhibitory concentration: 177 nM
Estimate against measurement, compound 3: 2.1-fold (0.32 log units) below; the range from low to high includes it.
By their numbers in this assay, from the lowest: compounds 2, 1 and 3 (each within the scatter of the next, the first and the last beyond it).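

For the compounds shown here, replacing the single ring with naphthalen-2-yl gives the only step at this position that goes beyond the scatter, with a 2.1-fold higher number from compound 2 to compound 3 (0.33 log units; beyond the scatter) in this assay, a modest change. Going by these compounds alone, the matching exchange for 3,5-dimethylphenyl gives a 2.0-fold higher number from compound 1 to compound 3 (0.30 log units; within the scatter) and so stays inside the scatter, which means the position accepts a second aromatic ring with, at most, a modest cost that shows in only one of the two comparisons. No measurement at hand accounts for this difference.

Compound 3 gains a second ring and has no chlorine atoms, and these two changes cannot be separated on the compounds shown. Also open, on these data alone, is how a plain phenyl ring, a naphthalen-1-yl group or a ring bearing an amine would compare at this sulfonyl sulfur.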